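Compound 1 to compound 4: bromo to hydrogen

A few compounds are considered here, and "the series" means these few. Any claim that something is new, unique, unknown or untested is made for them only; others in the source may bear on it.

Compound 1 `COc1cc(/C=N/Nc2nc(-c3ccc(Br)cc3)cs2)cc(Br)c1OC` stands only at a limit in an ADME assay on HUVEC cells (Homo sapiens) for inhibition, read by MTT assay, with a stated time of 48 h; a higher number here means a weaker inhibitor, a lower number a stronger inhibitor: compound 1 gives > 100000 nM, which is a limit of the assay and not a number. Compound 2 `COc1ccccc1-c1csc(N/N=C/c2ccc(F)c(F)c2)n1` gives > 100000 nM in this assay, again a limit. Compound 3 `Fc1ccc(/C=N/Nc2nc(-c3ccc(Br)cc3)cs2)cc1F` gives > 100000 nM, also a limit. Among the measured compounds shown here, the one step that can be traced, a step that the two limits leave unreadable from compound 2 to compound 3, is therefore of unreadable size. Compound 4 `COc1cc(/C=N/Nc2nc(-c3ccccc3)cs2)cc(Br)c1OC` differs from compound 1 by hydrogen in place of bromo on an aromatic carbon. For the measured compounds named here, no measured step bears directly on this change; every value shown sits at the same limit, (the limit of > 100000 nM in this assay, at which 3 of the 3 values shown sit). No step beyond the scatter is expected in this assay in either direction, so compound 4 is expected near 150000 nM (range 50000 nM to 500000 nM), most likely again a limit. The estimated step is a step that the limit leaves unreadable from compound 1 to compound 4.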

Compound 4, half-maximal inhibitory concentration: > 100000 nM
Compound 4 gave a limit, no number; the forecaster's own chance of this, stated with the estimate: 85%; the middle value is on the limit's open side.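

Among the compounds shown here, compound 1 and compound 4 both stand only at a limit, not a number, in this assay, so no step between them can be read. The compounds shown leave open whether hydrogen in place of bromo changes inhibition at all, and whether any change to the shared core gives a readable value: the limit of > 100000 nM in this assay, at which 4 of the 4 values shown sit.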